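The source may report more compounds than this note shows. Statements on the series, on what has been measured and on what is new or still open speak of the compounds shown alone.

Within the data shown here, compound 1 `CNC(=O)c1cc(Oc2ccc3nc(Nc4ccccc4)ncc3c2)ccn1` is one of only two compounds with a reading in a physicochemical assay for solubility, at pH 7; a higher number here means a more soluble compound, a lower number a less soluble compound. For compound 1 the reading is a limit of the assay, < 1000 nM. Compound 2 `CNC(=O)c1cc(Oc2ccc3nc(Nc4cccc(C(C)(C)C)c4)ccc3c2)ccn1` likewise gives a limit in this assay, < 1000 nM. Among the measured compounds shown here, both sit at the limit of < 1000 nM in this assay, at which 2 of the 2 values shown sit, so no step between measured compounds can be sized. Compound 3 `CNC(=O)c1cc(Oc2ccc3nc(Nc4ccccc4Oc4ccccc4)ncc3c2)ccn1` differs from compound 1 by phenoxy in place of hydrogen on an aromatic carbon. Because compound 1 already reads a limit, < 1000 nM, the expected step is a step that the limit leaves unreadable from compound 1 to compound 3, none beyond the scatter or a decrease. For compound 3 the estimated solubility is 300 nM, within 50 nM to 1000 nM, most likely again reported only as a limit.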

Compound 3, solubility: < 1000 nM
Compound 3: no number, only a limit; the forecaster's own chance of this, stated with the estimate: 90%; the middle value does not contradict the limit.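

Compound 1 and compound 3 both read only as limits, so no step between them can be read in this assay: the limit of < 1000 nM in this assay, at which 3 of the 3 values shown sit.

The compounds shown leave open what actual number each would give, and so whether phenoxy in place of hydrogen changes the reading at all.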